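A few compounds are considered here, and "the series" means these few. Any claim that something is new, unique, unknown or untested is made for them only; others in the source may bear on it.

Working notes on the series. In a functional assay on A549 cells (Homo sapiens) for cytotoxicity, read by MTT assay, with a stated time of 72 h (on this read-out lower numbers stand for stronger inhibition and higher numbers for weaker inhibition), compound 1 `COc1cc(Nc2nc3ccccc3nc2S(=O)(=O)c2ccccc2)cc(OC)c1OC` gives 9660 nM and compound 2 `COc1cc(Nc2nc3ccccc3nc2S(=O)(=O)c2ccc(C)cc2)cc(OC)c1OC` gives 5610 nM. Among the measured compounds shown here, the only single-point change measured so far is a 1.7-fold lower number from compound 1 to compound 2 (0.24 log units; within the scatter). Compound 3 `COc1cc(Nc2nc3ccccc3nc2S(=O)(=O)c2ccc(Br)cc2)cc(OC)c1` gives 15900 nM in this assay, the highest of the three numbers; its gap to compound 1 lies within the scatter, its gap to compound 2 beyond it. Compound 4 `COc1cc(Nc2nc3ccccc3nc2S(=O)(=O)c2ccc(Br)cc2)cc(OC)c1OC` differs from compound 3 by methoxy in place of hydrogen on an aromatic carbon, on an aromatic carbon of a six-membered aromatic ring of carbon only, ortho to two methoxy groups and para to a large group. For the measured compounds named here, no measured step follows this change: the one step measured concerns a different group at a different place, and compound 1 and compound 2, which carry the methoxy group that enters, differ from compound 3 in more than one place. The expectation is therefore no step beyond the scatter, a 1.6-fold lower number from compound 3 to compound 4 (0.20 log units; within the scatter). Compound 4 is expected to give 10000 nM in this assay, with a range from 4000 nM to 25000 nM.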

Compound 4, half-maximal inhibitory concentration: 6110 nM
Beside the measured number, compound 4's estimate is 1.6-fold (0.21 log units) above it; measured number inside the range.
By their numbers in this assay, from the lowest: compounds 2, 4, 1 and 3 (each within the scatter of the next, the first and the last beyond it).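

In this assay methoxy in place of hydrogen on the aromatic carbon ortho to two methoxy groups and para to a large group gives a 2.6-fold lower number from compound 3 to compound 4 (0.42 log units; beyond the scatter) as the first step read at this place, and it lies beyond the scatter. Among the compounds shown here, with that methoxy present, bromo in place of methyl gives a 1.1-fold higher number from compound 2 to compound 4 (0.04 log units; within the scatter) and bromo in place of hydrogen gives a 1.6-fold lower number from compound 1 to compound 4 (0.20 log units; within the scatter) so neither exchange separates its pair beyond the scatter, and the methoxy change is the only step here that does. No available evidence accounts for the size of the methoxy step.

For the compounds shown here, compound 3 is the only compound without this methoxy, so the step rests on the bromo compounds alone and its size with hydrogen or methyl in place of bromo remains open. As far as these compounds go, how an amine, a hydroxy group or a longer chain such as ethoxy would read at this place also remains open.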